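A few compounds are considered here, and "the series" means these few. Any claim that something is new, unique, unknown or untested is made for them only; others in the source may bear on it.

Compound 1 `CCCOCCn1c(N2CCCN(C)CC2)nc2ccccc21` gives 16 nM in a functional assay on ileum for inhibition of histamine H1 receptor (Cavia porcellus); on this read-out higher numbers stand for weaker inhibition and lower numbers for stronger inhibition.
Compound 2 `CCCCCN1CCN(c2nc3ccccc3n2CCOCC)CC1` gives 30 nM in this assay.
Compound 3 `CCCCCCn1c(N2CCN(C)CC2)nc2ccccc21` gives 26 nM in this assay.

Compound 3 stands between the other two on these three numbers, and both neighbours lie within the usual scatter of it: compound 2 with 30 nM and compound 1 with 16 nM. Compound 4 `CCSCCn1c(N2CCN(C)CC2)nc2ccccc21` has not been measured. It differs from compound 3 in one place: ethylsulfanyl in place of butyl on a saturated chain carbon, two bonds along the chain from an aromatic nitrogen. For the measured compounds named here, no measured pair shows this exact change, so the expected step from compound 3 to compound 4 is set at a 1.0-fold lower number from compound 3 to compound 4 (0.02 log units; within the scatter) in this assay, that is, no step beyond the scatter in either direction. Compound 4 is therefore estimated at 25 nM, with a range from 10 nM to 60 nM.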

Compound 4, half-maximal inhibitory concentration: 19 nM
Compound 4: middle estimate off by 1.3-fold (0.12 log units), on the high side; measured number inside the range.
By their numbers in this assay, from the lowest: compounds 1, 4, 3 and 2 (each within the scatter of the next).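

In this assay, ethylsulfanyl in place of butyl, on a saturated chain carbon, two bonds along the chain from an aromatic nitrogen, gives a 1.4-fold lower number from compound 3 to compound 4 (0.14 log units; within the scatter). For the compounds shown here, this is the first comparison of two compounds that differ in one place, and it shows that this position accepts a sulfur atom in the chain with no change beyond the scatter, even though ethylsulfanyl has one heavy atom fewer than butyl and a hydrogen-bond acceptor. As far as these compounds go, whether an amine or a carboxylic acid in place of butyl would be accepted as well remains open. Nothing measured here gives a reason for this result.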